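Triazole-linked enone series: ester in place of benzamide

The source may report more compounds than this note shows. Statements on the series, on what has been measured and on what is new or still open speak of the compounds shown alone.

Compound 1 `COc1cc(/C=C/C(C)=O)ccc1OCc1cn(-c2c(Cl)cccc2Cl)nn1` gives 2000 nM in a functional assay on HCT-116 cells (Homo sapiens) for antiproliferative activity, read by MTT assay, with a stated time of 48 h; on this read-out lower numbers stand for stronger inhibition and higher numbers for weaker inhibition. Compound 3 `COc1cc(/C=C/C(C)=O)ccc1OCc1cn(-c2ccc(C(F)(F)F)c(C(F)(F)F)c2)nn1` gives 57800 nM in this assay. Compound 2 `COc1cc(/C=C/C(C)=O)ccc1OCc1cn(-c2ccc(NC(=O)c3ccccc3)cc2)nn1` returns only a limit, > 100000 nM, in this assay. Compound 2 thus sits at the limit of > 100000 nM in this assay, at which 1 of the 3 values shown sits, with no number of its own, at the weak end of what has been measured. Compound 4 `CCOC(=O)c1ccc(-n2cc(COc3ccc(/C=C/C(C)=O)cc3OC)nn2)cc1` differs from compound 2 by ethoxycarbonyl in place of benzamido on an aromatic carbon. Among the measured compounds shown here, no measured pair differs in this one place, so the size of the step rests on the change alone. The step from compound 2 to compound 4 is expected to run toward stronger inhibition, roughly an at least 3.3-fold lower number from compound 2 to compound 4 (0.52 log units; beyond the scatter), beyond the usual scatter. Compound 4 is expected to give 30000 nM in this assay, between 5000 nM and 150000 nM.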

Compound 4, half-maximal inhibitory concentration: 78900 nM
Compound 4: the middle estimate sits 2.6-fold (0.42 log units) below what was measured; measured number inside the range.
By their numbers in this assay, from the lowest: compound 1; then compounds 3 and 4 (each within the scatter of the next). At a limit, above all of these: compound 2.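

With ethoxycarbonyl in place of benzamido on this aromatic carbon, para to a large group, compound 4 gives a number of its own, 78900 nM, in this assay. The change reads as an at least 1.2-fold lower number from compound 2 to compound 4 (0.10 log units; that floor lies within the scatter), so a real gain at this position is not established. The true size of the step cannot be told because compound 2 is held only by a limit: the limit of > 100000 nM in this assay, at which 1 of the 4 values shown sits.

Open, going by these compounds, is how a carboxylic acid, an amine or a longer ester chain would read at this place in this assay.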